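The compounds below may be only part of what the source reports. "The series", "measured", "known", "first", "only" and "open" are said of these compounds alone.

Compound 3, with structure `CCN(Cc1cccc(Br)c1)c1cccc(C(=O)N2CCc3ccc(OS(N)(=O)=O)cc3C2)c1`, is the reference point here. In an assay on HEK293 cells for inhibition of Steryl-sulfatase (Homo sapiens), tested at 0.1 uM (a higher number here means a stronger effect of the compound at the concentration tested, a lower number a weaker effect), compound 3 gives 20.9%, the smallest of the three numbers measured, although its gap to compound 1 is within the scatter. Compound 1, `CCN(Cc1ccc(Br)cc1)c1cccc(C(=O)N2CCc3ccc(OS(N)(=O)=O)cc3C2)c1`, gives 24.2% in this assay, and compound 2, `CCN(Cc1ccncc1)c1cccc(C(=O)N2CCc3ccc(OS(N)(=O)=O)cc3C2)c1`, gives 33.3%. The step of a number 12.4 percentage points lower from compound 2 to compound 3 (beyond the scatter) is the one clearly resolved difference among these three.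

Compound 4, `CCN(Cc1cccnc1)c1cccc(C(=O)N2CCc3ccc(OS(N)(=O)=O)cc3C2)c1`, has not yet been measured. It differs from compound 3 by pyridin-3-yl in place of 3-bromophenyl on a saturated chain carbon bound to a nitrogen on an aromatic ring. Among the measured compounds shown here, two measured steps bear on this change. The step of a number 12.4 percentage points lower from compound 2 to compound 3 (beyond the scatter) shows that exchanging a pyridinyl ring for a 3-bromophenyl ring lowered the read-out, and the step of a number 9.1 percentage points higher from compound 1 to compound 2 (within the scatter) points the same way, with the pyridinyl compound giving the higher number. Going back from 3-bromophenyl to a pyridinyl ring is therefore expected to raise the read-out in this assay by a modest amount.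

For compound 4 in this assay the estimate is 31%, in a range from 18% to 44%, which would mean an expected step of a number 10.1 percentage points higher from compound 3 to compound 4 (beyond the scatter).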

Compound 4, a percentage reported as inhibition, at one concentration (the size of the read-out at that concentration, not a potency): 14.3%
Estimate against measurement, compound 4: 16.7 percentage points above, and the stated range ends above it.
By their numbers in this assay, from the lowest: compounds 4, 3, 1 and 2 (each within the scatter of the next, the first and the last beyond it).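

The nitrogen's place in the pyridine ring matters at this position: in this assay, pyridin-3-yl in place of pyridin-4-yl gives a number 19 percentage points lower from compound 2 to compound 4 (beyond the scatter) and is the largest step in the series. A pyridinyl ring therefore does not by itself give a higher number, since the change from 3-bromophenyl gives a number 6.6 percentage points lower from compound 3 to compound 4 (within the scatter) and the change from 4-bromophenyl gives a number 9.9 percentage points lower from compound 1 to compound 4 (within the scatter), both too small to separate the compounds. The data shown contain no evidence that explains the gap between the two pyridinyl compounds.

As far as these compounds go, it remains open how pyridin-2-yl would compare with these two pyridinyl isomers, or an unsubstituted phenyl with the two bromophenyl compounds. From the compounds shown here alone, these read-outs come from a single concentration, so the relative potencies of the compounds also remain open.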